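Pyrimidine substituent replacement: cyclopropyl to pyrrolidinyl

The compounds below may be only part of what the source reports. "The series", "measured", "known", "first", "only" and "open" are said of these compounds alone.

Measured compounds:
compound 1, `CCOc1ncc(-c2nc(C(F)(F)F)sc2N2CCN(C(=O)Cn3nc(C)nc3C)[C@H](C)C2)cn1`; in a functional assay on U2OS cells for antagonist activity at C-X-C chemokine receptor type 3 (Homo sapiens), read by beta-arrestin recruitment (on this read-out lower numbers stand for stronger inhibition and higher numbers for weaker inhibition), compound 1 gives 173 nM
compound 2, `Cc1nc(C)n(CC(=O)N2CCN(c3sc(C(F)(F)F)nc3-c3cnc(OC4CCC4)nc3)C[C@H]2C)n1`; in this assay compound 2 gives 78 nM
compound 3, `Cc1nc(C)n(CC(=O)N2CCN(c3sc(C(F)(F)F)nc3-c3cnc(C4CC4)nc3)C[C@H]2C)n1`; in this assay compound 3 gives 349 nM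

Compound 3 has the highest number of the three. The step of a 2.0-fold higher number from compound 1 to compound 3 (0.30 log units; within the scatter) stays within the scatter, whereas the step of a 4.5-fold higher number from compound 2 to compound 3 (0.65 log units; beyond the scatter) lies beyond it, so only the gap to compound 2 counts as a real difference.

Compound 4, `Cc1nc(C)n(CC(=O)N2CCN(c3sc(C(F)(F)F)nc3-c3cnc(N4CCCC4)nc3)C[C@H]2C)n1`, differs from compound 3 in one place: pyrrolidin-1-yl in place of cyclopropyl on an aromatic carbon. The two measured steps that touch this position, a 4.5-fold higher number from compound 2 to compound 3 (0.65 log units; beyond the scatter) and a 2.0-fold higher number from compound 1 to compound 3 (0.30 log units; within the scatter), both run from a group bound through an oxygen to a cyclopropyl bound through carbon, and both go toward higher numbers. The step into compound 4 goes the other way, from cyclopropyl to a five-membered ring bound through nitrogen, carrying one hydrogen-bond acceptor as the alkoxy groups of compounds 1 and 2 do. On that basis a modest move toward lower numbers is expected, a 2.7-fold lower number from compound 3 to compound 4 (0.43 log units; beyond the scatter), of a size between the two measured steps. Compound 4 is therefore estimated at 130 nM in this assay, with a range from 45 nM to 400 nM.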

Compound 4, half-maximal inhibitory concentration: 523 nM
Compound 4: middle estimate off by 4.0-fold (0.60 log units), on the low side; the measured number lies above the stated range.
By their numbers in this assay, from the lowest: compound 2; then compounds 1, 3 and 4 (each within the scatter of the next, the first and the last beyond it).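

In this assay, pyrrolidin-1-yl on the aromatic carbon between two ring nitrogen atoms gives a 1.5-fold higher number from compound 3 to compound 4 (0.18 log units; within the scatter) and so is not told apart from cyclopropyl, although it brings 1 hydrogen-bond acceptor where cyclopropyl has 0. Pyrrolidin-1-yl does separate from both oxygen-bound groups, with a 6.7-fold higher number from compound 2 to compound 4 (0.83 log units; beyond the scatter) against cyclobutyloxy and a 3.0-fold higher number from compound 1 to compound 4 (0.48 log units; beyond the scatter) against ethoxy, so among these compounds a hydrogen-bond acceptor on a ring bound through nitrogen does not match the oxygen-bound groups, while compound 1 stays unseparated from the cyclopropyl compound 3. No measurement on hand accounts for these differences.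

The compounds shown leave open whether the oxygen link or the cyclobutyl ring goes with the lowest number, which a cyclobutyl bound directly through carbon or a cyclobutylamino group would help to settle. Also open, going by these compounds, is whether pyrrolidin-1-yl stands for nitrogen-bound groups in general, since a morpholine or an open-chain dimethylamino group could read differently at this position.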